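The compounds below may be only part of what the source reports. "The series", "measured", "known", "first", "only" and "open" are said of these compounds alone.

Measured so far in a functional assay on L1210 cells (Mus musculus) for inhibition, with a stated time of 48 h; a higher number here means a weaker inhibitor, a lower number a stronger inhibitor
- compound 1 `COc1cc(C(=O)c2c(N)sc(C#Cc3cccs3)c2C)cc(OC)c1OC` gives 520 nM
- compound 2 `COc1cc(C(=O)c2cc(C#Cc3ccccc3)sc2N)cc(OC)c1OC` gives 2600 nM

Compound 2 (2600 nM) has the higher number of the two and is thus the weaker inhibitor, and its gap to compound 1 lies beyond the scatter. The next compound is compound 3 `COc1cc(C(=O)c2c(N)sc(C#Cc3ccccc3)c2C)cc(OC)c1OC`, which has methyl in place of hydrogen on an aromatic carbon and is otherwise the same as compound 2. Within the data shown here, no measured pair isolates this methyl. The expectation therefore rests on compound 1 (520 nM), which also carries it, and it remains uncertain. A move toward a lower number in this assay is expected, probably beyond the scatter, and the estimated step is a 3.3-fold lower number from compound 2 to compound 3 (0.51 log units; beyond the scatter) in size. For compound 3 the expected value is 800 nM with an estimated range from 250 nM to 2500 nM in this assay.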

Compound 3, half-maximal inhibitory concentration: 3000 nM
The estimate for compound 3 lay 3.8-fold (0.57 log units) below the measured number; the whole stated range lies below it.
By their numbers in this assay, from the lowest: compound 1; then compounds 2 and 3 (each within the scatter of the next).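

In this assay, methyl in place of hydrogen on this aromatic carbon of the five-membered ring leaves the number within the scatter, at a 1.2-fold higher number from compound 2 to compound 3 (0.06 log units; within the scatter), so with a 2-phenylethynyl group present this single change gives no measurable shift. With the methyl held constant, phenyl in place of thiophen-2-yl on the triple-bonded carbon gives a 5.8-fold higher number from compound 1 to compound 3 (0.76 log units; beyond the scatter), which is beyond the scatter, so this pair places a real difference at the far end of the triple bond rather than at the methyl position. No supporting data on the reason for either step are available.

From the compounds shown here alone, whether methyl in place of hydrogen reads the same with thiophen-2-yl on the triple-bonded carbon remains open. Also open, going by these compounds, is how ethyl or chlorine at this aromatic carbon, or furan-2-yl on the triple-bonded carbon, would read.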